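The source may hold more compounds than are shown below. What is called first, only, known or untested is meant among the compounds shown, and "the series" means these compounds.

Compound 1 `COc1cccc(-c2nc3c(-c4ccc(Cl)cc4)n[nH]c3c(=O)n2NC(=O)c2ccccc2)c1`: 17900 nM
Compound 2 `CCCCc1nc2c(-c3ccc(Cl)cc3)n[nH]c2c(=O)n1NC(=O)c1ccccc1`: 29100 nM
Compound 3 `CCCCCc1nc2c(-c3ccc(Cl)cc3)n[nH]c2c(=O)n1NC(=O)c1ccccc1`: 22100 nM

All three numbers come from a functional assay on DU-145 cells (Homo sapiens) for inhibition, read by MTT assay, with a stated time of 2 days; on this read-out higher numbers stand for weaker inhibition of growth and lower numbers for stronger inhibition of growth. The measured compounds share a core and a benzamido group and differ only in the substituent on one aromatic carbon of that core. Compound 3 sits level with the other two: a 1.2-fold higher number from compound 1 to compound 3 (0.09 log units; within the scatter) and a 1.3-fold lower number from compound 2 to compound 3 (0.12 log units; within the scatter), and the remaining pair behaves the same way, a 1.6-fold higher number from compound 1 to compound 2 (0.21 log units; within the scatter). Among the measured compounds shown here, no measured compound is separated from another beyond the scatter.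

Compound 4 `CCCCCc1nc2c(-c3ccc(Cl)cc3)n[nH]c2c(=O)n1NC(=O)c1cccc(C)c1` keeps everything of compound 3 and alters only the benzamido group: methyl in place of hydrogen on an aromatic carbon. For the measured compounds named here, none of the measured steps touches this ring; all three move the group on the other aromatic carbon of the core, and all three stay within the scatter. Going by the values given here, there is thus no measured step that bears directly on the change from compound 3 to compound 4. What can be said is that every change measured in this assay has left the number essentially where it was. The expectation is therefore no step beyond the scatter, a 1.0-fold lower number from compound 3 to compound 4 (0.00 log units; within the scatter). For compound 4 in this assay the estimate is 22000 nM, with a range from 10000 nM to 48000 nM.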

Compound 4, concentration for 50% growth inhibition: 12900 nM
Beside the measured number, compound 4's estimate is 1.7-fold (0.23 log units) above it; measured number inside the range.
By their numbers in this assay, from the lowest: compounds 4, 1, 3 and 2 (each within the scatter of the next, the first and the last beyond it).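

Among the compounds shown here, this is the first reading on the benzamido ring, since all earlier steps moved the group on the core. In this assay, placing methyl on an aromatic carbon of this ring, meta to a large group, gives a 1.7-fold lower number from compound 3 to compound 4 (0.23 log units; within the scatter) and so leaves compound 4 level with compound 3: benzamido to ((3-methylphenyl)carbonyl)amino is tolerated at this position, and the ring, like the core substituent, has so far produced no step beyond the scatter. No accompanying measurement bears on this result, so the reading stands as a bare number with no explanation attached.

As far as these compounds go, a single small group on a single ring carbon says little about the ring as a whole, so it remains open whether a methoxy group, a carboxylic acid, an amine or a chlorine at this carbon, or methyl on another carbon of the same ring, would move the number beyond the scatter. From the compounds shown here alone, it also remains open whether the methyl behaves the same way with butyl or 3-methoxyphenyl on the core in place of pentyl, as the present step rests on the pentyl compounds alone.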